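The compounds below may be only part of what the source reports. "The series", "measured", "known", "first", "only" and "open" are said of these compounds alone.

Measured in an ADME assay on KB cells (Homo sapiens) for cytotoxicity, read by MTT assay, with a stated time of 72 h; on this read-out higher numbers stand for weaker inhibition and lower numbers for stronger inhibition:
Compound 1 `COc1ccc(C2=C(c3cc(OC)c(OC)c(OC)c3)C(=O)CC2O[SiH2]C(C)(C)C)cc1`: > 100 ug/mL, a limit of the assay
Compound 2 `COc1cc(C2=C(c3cc(C)c(OC)c(C)c3)C(O[SiH2]C(C)(C)C)CC2=O)cc(OC)c1OC`: 40 ug/mL

Among the measured compounds shown here, compound 2, at 40 ug/mL, holds the only actual number in this assay. The value of compound 1 is a limit of the assay. Compound 3 `COc1ccc(C2=C(c3cc(OC)c(OC)c(OC)c3)C(=O)CC2O[SiH2]C(C)(C)C)cc1O` has not yet been measured. Relative to compound 2, it carries 3-hydroxy-4-methoxyphenyl in place of 4-methoxy-3,5-dimethylphenyl on a double-bonded ring carbon. For the measured compounds named here, only one measured step bears on this ring carbon, an at least 2.5-fold lower number from compound 1 to compound 2 (0.39 log units; beyond the scatter). That step rests on (the limit of > 100 ug/mL in this assay, at which 1 of the 2 values shown sits), so its true size is open. It shows that a change of this group can move the read-out, but it does not fix a direction for the new group. No step beyond the scatter is therefore expected as the central case, though with wide uncertainty, leaning slightly towards a lower number. The estimate means an expected 1.6-fold lower number from compound 2 to compound 3 (0.20 log units; within the scatter). Compound 3 is estimated at 25 ug/mL, with an expected range of 4 ug/mL to 100 ug/mL.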

Compound 3, half-maximal inhibitory concentration: 6.5 ug/mL
Estimate against measurement, compound 3: 3.8-fold (0.59 log units) above; the measured number falls inside the stated range.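

With actual numbers at both ends, the change on the double-bonded ring carbon in this assay gives a 6.2-fold lower number from compound 2 to compound 3 (0.79 log units; beyond the scatter), so this position now has a step of fixed size, which the earlier step could not provide. The comparison with the closest relative is also new: hydroxy in place of hydrogen on an aromatic carbon, the only difference between these two compounds, gives an at least 15-fold lower number from compound 1 to compound 3 (1.18 log units; beyond the scatter), which shows that this single group is enough to move the read-out beyond the scatter. The true size of that second step remains open because it rests on a limit of the assay: the limit of > 100 ug/mL in this assay, at which 1 of the 3 values shown sits.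

From the compounds shown here alone, it remains open whether an amine or a fluorine on the same aromatic carbon would move the read-out as the hydroxy does. The effect of replacing the hydroxy with an ethoxy group is equally unresolved.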